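A few compounds are considered here, and "the series" means these few. Any claim that something is new, unique, unknown or untested is made for them only; others in the source may bear on it.

Of the compounds shown here, two have so far been measured in an assay on isolated protein for binding affinity to histamine H2 receptor (Homo sapiens); a lower number here means a stronger inhibitor, a higher number a weaker inhibitor. Compound 1 `O=C(c1ccc(OCCCN2CC[C@H](NS(=O)(=O)c3ccccc3)C2)cc1)C1CC1` gives 1200 nM. Compound 2 `Cc1ccccc1S(=O)(=O)N[C@H]1CCN(CCCOc2ccc(C(=O)C3CC3)cc2)C1` gives 2200 nM, the higher of the two numbers, but the step of a 1.8-fold higher number from compound 1 to compound 2 (0.26 log units; within the scatter) lies within the scatter, so the two values cannot be told apart. Compound 3 `CCc1ccc(S(=O)(=O)N[C@H]2CCN(CCCOc3ccc(C(=O)C4CC4)cc3)C2)cc1` has not yet been measured. It differs from compound 2 in one place: 4-ethylphenyl in place of 2-methylphenyl on a sulfonyl sulfur. Among the compounds with values here, the only measured step that bears on this change, since it also alters the same aromatic ring on the sulfonyl sulfur, is a 1.8-fold higher number from compound 1 to compound 2 (0.26 log units; within the scatter), and that step stayed within the scatter. Nothing measured suggests that swapping one substituted phenyl for another on this position should move the number beyond the scatter, so for a 1.1-fold lower number from compound 2 to compound 3 (0.04 log units; within the scatter) no step beyond the scatter is expected. Compound 3 is therefore estimated at 2000 nM, with a range from 700 nM to 6000 nM.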

Compound 3, inhibition constant: 330 nM
Estimate against measurement, compound 3: 6.1-fold (0.78 log units) above; the measured number lies below the stated range.
By their numbers in this assay, from the lowest: compound 3; then compounds 1 and 2 (each within the scatter of the next).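

In this assay the aromatic ring on the sulfonyl sulfur now proves able to shift the number: 4-ethylphenyl in place of 2-methylphenyl gives a 6.7-fold lower number from compound 2 to compound 3 (0.82 log units; beyond the scatter) and so moves beyond the scatter, which the earlier step at this place did not. Adding the ethyl group to the ring that carries no such group gives a 3.6-fold lower number from compound 1 to compound 3 (0.56 log units; beyond the scatter) and also moves beyond the scatter, whereas methyl in place of hydrogen in compound 2 stayed within it. No measurement at hand explains this difference.

The compounds shown leave open whether the ethyl group itself or its place on the ring counts, as compound 2 and compound 3 differ in both. Also open, going by these compounds, is whether a longer chain such as propyl, an amine or a carboxylic acid on this ring would lower the number further or raise it again.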